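The source may hold more compounds than are shown below. What is called first, only, known or untested is meant among the compounds shown, and "the series" means these compounds.

Of the compounds shown here, three that share one core have been measured in an assay on CHO cells for displacement of a labelled ligand from adenosine receptor A3 (Homo sapiens), read by scintillation counting, with a stated time of 3 h; a higher number here means a weaker inhibitor, a lower number a stronger inhibitor. Compound 1 `Cn1c(-c2ccc(O)cc2)nc2c(NC3CCCC3)ncnc21` gives 521 nM. Compound 2 `COc1ccc(-c2nc3c(NC4CCCC4)ncnc3n2C)cc1` gives 1850 nM. Compound 3 `Cc1cccc(-c2nc3c(NC4CCCC4)ncnc3n2C)c1` gives 510 nM, the lowest of the three numbers, although compound 1 stands within the scatter of it, so the two cannot be ranked. Among the steps between them, a 3.6-fold higher number from compound 1 to compound 2 (0.55 log units; beyond the scatter) is modest, a 1.0-fold lower number from compound 1 to compound 3 (0.01 log units; within the scatter) stays within the scatter, and a 3.6-fold lower number from compound 2 to compound 3 (0.56 log units; beyond the scatter) is modest.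

Compound 4 `Cn1c(-c2ccccc2Cl)nc2c(NC3CCCC3)ncnc21` has not yet been measured. It differs from compound 3 in one place: 2-chlorophenyl in place of 3-methylphenyl on an aromatic carbon. For the measured compounds named here, the steps that swapped this same aromatic group, leading to compound 3 from compound 1 and from compound 2, bear on this change; they ranged from within the scatter to modest, with no direct precedent for a chlorine in this group. A modest step in this assay in either direction, or none beyond the scatter, is therefore expected. Compound 4 is estimated at 800 nM, with a range from 250 nM to 2500 nM, an expected step of a 1.6-fold higher number from compound 3 to compound 4 (0.20 log units; within the scatter).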

Compound 4, inhibition constant: 720 nM
The estimate for compound 4 lay 1.1-fold (0.05 log units) above the measured number; the measured number falls inside the stated range.
By their numbers in this assay, from the lowest: compounds 3, 1 and 4 (each within the scatter of the next); then compound 2.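

At this aromatic carbon of the shared core, the first chlorine-bearing group fits with the earlier picture in this assay: 2-chlorophenyl in place of 3-methylphenyl gives a 1.4-fold higher number from compound 3 to compound 4 (0.15 log units; within the scatter) and 2-chlorophenyl in place of 4-hydroxyphenyl gives a 1.4-fold higher number from compound 1 to compound 4 (0.14 log units; within the scatter) so compound 1, compound 3 and compound 4 cannot be ranked. Compound 2 now stands apart from all three, and 2-chlorophenyl in place of 4-methoxyphenyl gives a 2.6-fold lower number from compound 2 to compound 4 (0.41 log units; beyond the scatter) as the step that shows it. Nothing measured here offers a reason for any of these steps.

This step changes both the atom and where it sits on the phenyl ring, so the two changes cannot be told apart. From the compounds shown here alone, how an amine or a carboxylic acid on that ring would behave also remains open.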